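A few compounds are considered here, and "the series" means these few. Any claim that something is new, unique, unknown or untested is made for them only; others in the source may bear on it.

Compound 1 `CC(=O)Nc1ccc(O)c(C(=O)/C=C/c2cccc(F)c2)c1` gives 78600 nM in an ADME assay on THP-1 cells (Homo sapiens) for cytotoxicity, read by flow cytometry and propidium iodide staining, with a stated time of 72 h; a higher number here means a weaker inhibitor, a lower number a stronger inhibitor. Compound 2 `CC(=O)Nc1ccc(O)c(C(=O)/C=C/c2ccc(C(F)(F)F)cc2)c1` gives 15500 nM. Compound 3 `CC(=O)Nc1ccc2oc(-c3ccccc3)cc(=O)c2c1` gives 97000 nM.

Among these three, compound 3 has the highest number in this assay, although its gap to compound 1 is within the scatter of repeated measurements, so the two cannot be ranked against each other. Compound 2 stands apart, with a number beyond the scatter below that of compound 3.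

Compound 4 `COc1ccccc1-c1cc(=O)c2cc(NC(C)=O)ccc2o1` shares the core of compound 3 and differs from it in a single place: methoxy in place of hydrogen on an aromatic carbon on an aromatic carbon of a six-membered aromatic ring of carbon only, ortho to a large group. Within the data shown here, no measured pair in this set shows the effect of such a change, so the step can only be guessed. Since nothing in the data on compound 3 points to either a sharp rise or a sharp fall, compound 4 is expected to stay close to its parent, and the step from compound 3 to compound 4 is estimated at a 1.2-fold lower number from compound 3 to compound 4 (0.08 log units; within the scatter), which lies within the scatter. Compound 4 is therefore estimated to give 80000 nM in this assay, with a range from 30000 nM to 200000 nM.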

Compound 4, half-maximal inhibitory concentration: 50000 nM
The estimate for compound 4 lay 1.6-fold (0.20 log units) above the measured number; low and high end bracket the measured number.
By their numbers in this assay, from the lowest: compound 2; then compounds 4, 1 and 3 (each within the scatter of the next).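

Among these compounds, the step from hydrogen to methoxy on this aromatic carbon, ortho to a large group, is the first change in one place that can be read in this set. In this assay it amounts to a 1.9-fold lower number from compound 3 to compound 4 (0.29 log units; within the scatter), so adding methoxy, with its 2 heavy atoms and 1 hydrogen-bond acceptor, at this position leaves the number indistinguishable from that of the parent within the usual scatter of repeated measurements. No measurement to hand bears on what lies behind the size of this step.

The compounds shown leave open whether a hydroxyl group, an amine or a longer chain such as ethoxy would also leave the number in this assay within the scatter at this position, or would instead produce a step beyond it. They also leave open whether methoxy would give a similar step on the other aromatic carbons of this ring, since this single pair speaks for one position and one group only.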